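This account rests on a few compounds, and the source may have more. Where it says the series, first, only, none or still open, it means among the compounds named here.

Compound 1 `C=C1[C@H](C)CCC[C@]1(C)CC/C(C)=C/CC1=C(O)C(=O)C=C(N[C@@H](C(=O)O)[C@H](C)O)C1=O` carries a side chain in which a 1-hydroxyethyl group sits on a saturated chain carbon bound to an amine nitrogen and a carbonyl carbon. In an ADME assay on KB cells (Homo sapiens) for cytotoxicity, with a stated time of 48 h (on this read-out lower numbers stand for stronger inhibition and higher numbers for weaker inhibition), compound 1 gives > 10 ug/mL, which is a limit of the assay rather than a number. Compound 2 `C=C1[C@H](C)CCC[C@]1(C)CC/C(C)=C/CC1=C(O)C(=O)C=C(NCC(=O)O)C1=O` differs from compound 1 by hydrogen in place of 1-hydroxyethyl on a saturated chain carbon bound to an amine nitrogen and a carbonyl carbon, and in this assay compound 2 gives 4 ug/mL. The resulting step, an at least 2.5-fold lower number from compound 1 to compound 2 (0.39 log units; beyond the scatter), is the only measured effect of this change. Compound 3 `CC1=CCC[C@](C)(CC/C(C)=C/CC2=C(O)C(=O)C=C(N[C@@H](C(=O)O)[C@H](C)O)C2=O)[C@@H]1C` keeps the side chain of compound 1 but has a different core: a group of 9 heavy atoms (9 carbon; one six-membered non-aromatic ring of carbon only) in place of a group of 9 heavy atoms (9 carbon; one six-membered non-aromatic ring of carbon only), on a saturated chain carbon, two bonds along the chain from a double-bonded chain carbon. In this assay compound 3 gives > 10 ug/mL, again a limit of the assay. The step that the two limits leave unreadable from compound 1 to compound 3 cannot be read because both values rest at the limit of > 10 ug/mL in this assay, at which 2 of the 3 values shown sit. Compound 4 `CC1=CCC[C@](C)(CC/C(C)=C/CC2=C(O)C(=O)C=C(NCC(=O)O)C2=O)[C@@H]1C` arises from compound 3 by the same change, (hydrogen in place of 1-hydroxyethyl on a saturated chain carbon bound to an amine nitrogen and a carbonyl carbon). As the two starting points share the limit of the limit of > 10 ug/mL in this assay, at which 2 of the 3 values shown sit, a step of roughly the size seen in an at least 2.5-fold lower number from compound 1 to compound 2 (0.39 log units; beyond the scatter) is expected here too. From compound 3 to compound 4 the expected step is therefore an at least 2.0-fold lower number from compound 3 to compound 4 (0.30 log units; that floor lies within the scatter). Compound 4 is estimated to give 5 ug/mL, with a likely range from 2 ug/mL to 15 ug/mL.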

Compound 4, half-maximal inhibitory concentration: 5.4 ug/mL
Compound 4: the middle estimate sits 1.1-fold (0.03 log units) below what was measured; measured number inside the range.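

In this assay, putting hydrogen in place of 1-hydroxyethyl on the core of compound 3 gives an at least 1.8-fold lower number from compound 3 to compound 4 (0.26 log units; that floor lies within the scatter), so the number can only have fallen, as it did on the core of compound 1, but this second step is not shown to lie beyond the scatter. The change therefore carries over in direction, while nothing can be said about whether its size is the same on both cores: the same change on two cores in this assay, an at least 2.5-fold lower number (0.39 log units; beyond the scatter) from compound 1 to compound 2 and an at least 1.8-fold lower number (0.26 log units; that floor lies within the scatter) from compound 3 to compound 4; the limit leaves it open whether they differ With hydrogen in place, the step between the two cores is a 1.4-fold higher number from compound 2 to compound 4 (0.13 log units; within the scatter), whereas the matching step with 1-hydroxyethyl in place cannot be read: the limit of > 10 ug/mL in this assay, at which 2 of the 4 values shown sit.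

The compounds shown leave open how the number would move with a methyl group or a longer chain on that same carbon, or with an amide in place of the carboxylic acid. They also leave open whether a hydroxymethyl group would behave more like 1-hydroxyethyl or more like hydrogen.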